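Swapping Ethyl for Bromo: An Expected Cell Assay Result

This account rests on a few compounds, and the source may have more. Where it says the series, first, only, none or still open, it means among the compounds named here.

Of the compounds shown here, two have been measured in a functional assay on HeLa cells (Homo sapiens) for inhibition, read by MTT assay, with a stated time of 72 h; a higher number here means a weaker inhibitor, a lower number a stronger inhibitor. Compound 1 `CCCCCCCCCCCCc1ccc(C(=O)/C=C/C(=O)O)cc1` gives 5820 nM. Compound 2 `CCc1ccc(C(=O)/C=C/C(=O)O)cc1` gives 27800 nM, the highest of the two numbers, and its gap to compound 1 lies beyond the usual scatter, so compound 2 is the weaker inhibitor of the pair. Compound 3 `O=C(O)/C=C/C(=O)c1ccc(Br)cc1` has not yet been measured in this assay. It differs from compound 2 in one place: bromo in place of ethyl on an aromatic carbon. Going by the values given here, neither the leaving group nor the entering group carries hydrogen-bond donors or acceptors, and no measured pair shows what this exchange does in this assay. The step is therefore expected to be modest, likely within the usual scatter and in no firm direction, as a 1.1-fold lower number from compound 2 to compound 3 (0.05 log units; within the scatter) states. Compound 3 is accordingly expected to give about 25000 nM in this assay, with a range from 10000 nM to 60000 nM.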

Compound 3, half-maximal inhibitory concentration: 18700 nM
The estimate for compound 3 lay 1.3-fold (0.13 log units) above the measured number; low and high end bracket the measured number.
By their numbers in this assay, from the lowest: compound 1; then compounds 3 and 2 (each within the scatter of the next).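

In this assay, bromo in place of ethyl on an aromatic carbon gives a 1.5-fold lower number from compound 2 to compound 3 (0.17 log units; within the scatter) and so leaves the two compounds indistinguishable by this read-out. The earlier compounds shown here held no pair that tested this exchange, and now a single bromine atom is seen to stand in for the two carbons of ethyl at this position with no difference that can be told from ordinary repeat variation. The data shown offer no measurement that could explain this outcome.

The compounds shown leave open whether an amine or a methoxy group on this same aromatic carbon would shift the number beyond the scatter. They also leave open whether a chlorine atom would behave as bromo does here, and one pair cannot show whether this exchange would give a similar result on a different core.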